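Swapping a Ring Amine for a Ring Ether

A few compounds are considered here, and "the series" means these few. Any claim that something is new, unique, unknown or untested is made for them only; others in the source may bear on it.

Of the compounds shown here, two have so far been measured in an assay on cells for antagonist activity at transient receptor potential cation channel subfamily V member 1 (Homo sapiens), read by FLIPR and calcium flux, with a stated time of 6 min; on this read-out higher numbers stand for weaker inhibition and lower numbers for stronger inhibition. Compound 1 `CCCN(CCC)c1nc(C(C)(C)C)ccc1CNC(=O)C(C)c1ccc(NS(C)(=O)=O)c(F)c1` gives 2.5 nM in this assay. Compound 2 `CC(C(=O)NCc1ccc(C(C)(C)C)cc1N1CCCC1)c1ccc(NS(C)(=O)=O)c(F)c1` gives 8.1 nM in this assay, which is the higher of the two numbers; the gap to compound 1 lies beyond the usual scatter of repeated measurements, so compound 2 is the weaker inhibitor of the pair on the numbers shown.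

Compound 3 `CC(C(=O)NCc1ccc(C(C)(C)C)cc1OC1CCCC1)c1ccc(NS(C)(=O)=O)c(F)c1` has not yet been measured. It differs from compound 2 in a single place: cyclopentyloxy in place of pyrrolidin-1-yl on an aromatic carbon. For the measured compounds named here, no measured pair in this small set shows the effect of such a change, so the expectation rests only on the two numbers above and on the nature of the exchange. With a five-membered ring kept in place and the nitrogen link replaced by an oxygen link, a modest step is expected, most likely toward a somewhat higher number than compound 2 but not far beyond the scatter; the expected step is a 1.5-fold higher number from compound 2 to compound 3 (0.17 log units; within the scatter). Compound 3 is therefore estimated to give 12 nM in this assay, within a range of 4 nM to 40 nM.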

Compound 3, inhibition constant: 1.8 nM
For compound 3 the middle estimate is 6.7-fold (0.82 log units) above the measured one; the measured number lies below the stated range.
By their numbers in this assay, from the lowest: compounds 3 and 1 (each within the scatter of the next); then compound 2.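

For the compounds shown here, at this position, on an aromatic carbon ortho to a large group and meta to a tert-butyl group, the exchange of pyrrolidin-1-yl for cyclopentyloxy gives a 4.5-fold lower number from compound 2 to compound 3 (0.65 log units; beyond the scatter) in this assay and supplies the first measured step in this set. The position is therefore sensitive to the group it carries, even when a five-membered non-aromatic ring stays in place and the entering and leaving groups have the same counts of hydrogen-bond donors and acceptors and no net charge. The change replaces a ring holding nitrogen with a ring of carbon only joined through oxygen and adds one heavy atom, but nothing measured here accounts for the step.

This single pair cannot separate the contribution of the oxygen link from that of the all-carbon ring, and it leaves open whether the same exchange would give a similar step on another core. As far as these compounds go, how a cyclopentylamino group, a cyclopentyl group joined directly to the aromatic carbon or a smaller methoxy group would stand at this position also remains open.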